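A few compounds are considered here, and "the series" means these few. Any claim that something is new, unique, unknown or untested is made for them only; others in the source may bear on it.

Working notes on the series. Compound 1 `COc1ccc2c(/C=C/C(=O)c3cc(OC)c(OC)c(SC)c3)cn(C)c2c1` in a functional assay on HCT-8 cells (Homo sapiens) for antiproliferative activity, read by MTT assay, with a stated time of 48 h (on this read-out higher numbers stand for weaker inhibition and lower numbers for stronger inhibition), gives 157 nM. Compound 2 `COc1ccc2c(/C=C(\C)C(=O)c3cc(OC)c(OC)c([Se]C)c3)c[nH]c2c1` gives 29 nM in this assay, and compound 3 `COc1cc(C(=O)/C(C)=C/c2c[nH]c3ccccc23)cc([Se]C)c1OC` gives 32 nM. Compound 1 carries the highest number of the three; how its core differs from that of compound 2 is not broken down here, and the two values show only a gap beyond the scatter. From compound 2 to compound 3 the change is hydrogen in place of methoxy on an aromatic carbon, and the step measured is a 1.1-fold higher number from compound 2 to compound 3 (0.04 log units; within the scatter). Compound 4 `COc1cc(C(=O)/C=C/c2cn(C)c3ccccc23)cc(SC)c1OC`, not yet measured, carries the same change made from compound 1: hydrogen in place of methoxy on an aromatic carbon. The step expected for compound 4 is a 1.1-fold higher number from compound 1 to compound 4 (0.03 log units; within the scatter), a guess that rests on the earlier pair because a 1.1-fold higher number from compound 2 to compound 3 (0.04 log units; within the scatter) hardly moved. Compound 4 is therefore expected to give about 170 nM, somewhere from 80 nM to 380 nM.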

Compound 4, half-maximal inhibitory concentration: 210 nM
Estimate against measurement, compound 4: 1.2-fold (0.09 log units) below; measured number inside the range.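

In this assay, hydrogen in place of methoxy on an aromatic carbon gives a 1.3-fold higher number from compound 1 to compound 4 (0.13 log units; within the scatter), which matches what was seen on the other core. The change carries from one core to the other with no difference that can be told apart: the same change on two cores in this assay, a 1.1-fold higher number (0.04 log units; within the scatter) from compound 2 to compound 3 and a 1.3-fold higher number (0.13 log units; within the scatter) from compound 1 to compound 4, 1.2-fold (0.08 log units) apart, within the scatter of two such steps. This shows agreement across these two pairs only, and it does not show that the change would stay within the scatter on any further core.

Open, from the compounds shown here alone, is whether another group at this place, such as a hydroxy group, an amine or a chlorine atom, would move the number beyond the scatter. Also open, going by these compounds, is which of the differences between the core of compound 1 and that of compound 2 goes with the gap between their values.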